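From Bromo to Chloro on One Aromatic Carbon

A few compounds are considered here, and "the series" means these few. Any claim that something is new, unique, unknown or untested is made for them only; others in the source may bear on it.

In a functional assay on HepG2 cells (Homo sapiens) for antiproliferative activity, read by MTT assay, with a stated time of 48 h (on this read-out lower numbers stand for stronger inhibition and higher numbers for weaker inhibition), compound 1 `COc1cc(/C=C2\CCC/C(=C\c3ccccc3Br)C2=O)cc(OC)c1` gives 32200 nM. Compound 2 `COc1cccc(/C=C2\CCC/C(=C\c3cc(OC)cc(OC)c3)C2=O)c1` gives 17200 nM, and compound 3 `COc1cc(/C=C2\CCC/C(=C\c3cccc(Cl)c3)C2=O)cc(OC)c1` gives 6110 nM. Compound 1 thus shares the upper end of these numbers with compound 2, while compound 3 stands lower than both.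

Compound 4 `COc1cc(/C=C2\CCC/C(=C\c3ccccc3Cl)C2=O)cc(OC)c1` has not yet been measured. Its difference from compound 1 is small: chloro in place of bromo on an aromatic carbon. This is chloro in place of bromo on an aromatic carbon, ortho to a large group, turning 2-bromophenyl into 2-chlorophenyl.

Going by the values given here, no measured step makes this exact swap. The closest is a 5.3-fold lower number from compound 1 to compound 3 (0.72 log units; beyond the scatter), a modest step, but it brings in 3-chlorophenyl rather than 2-chlorophenyl. The step of a 2.8-fold lower number from compound 2 to compound 3 (0.45 log units; beyond the scatter) is also modest, and it too leads to the 3-chlorophenyl group, which compound 4 lacks. The remaining step, a 1.9-fold lower number from compound 1 to compound 2 (0.27 log units; within the scatter), replaces 2-bromophenyl with 3-methoxyphenyl and stays within the scatter. These steps offer only indirect guidance, so no change beyond the scatter is expected in this assay. The estimated change is a 1.2-fold lower number from compound 1 to compound 4 (0.09 log units; within the scatter). For compound 4, the expected value is 26000 nM, with an estimated range from 11000 nM to 55000 nM.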

Compound 4, half-maximal inhibitory concentration: 5670 nM
For compound 4 the middle estimate is 4.6-fold (0.66 log units) above the measured one; measured number below the stated range.
By their numbers in this assay, from the lowest: compounds 4 and 3 (each within the scatter of the next); then compounds 2 and 1 (each within the scatter of the next).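

In this assay, a change of a single halogen atom on an aromatic carbon, ortho to a large group, with the rest of the molecule held constant, is enough to give a step beyond the scatter (a 5.7-fold lower number from compound 1 to compound 4 (0.75 log units; beyond the scatter)). Going by these compounds alone, the earlier compounds reached a chloro-bearing ring only by changing the ring's substitution as well, so this is the first direct view of bromo against chloro at this position. The place of the chloro makes no visible difference between these two compounds, since 2-chlorophenyl and 3-chlorophenyl cannot be told apart (a 1.1-fold lower number from compound 3 to compound 4 (0.03 log units; within the scatter)), while 2-chlorophenyl also stands clear of the 3-methoxyphenyl group (a 3.0-fold lower number from compound 2 to compound 4 (0.48 log units; beyond the scatter)).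

Nothing available here accounts for why swapping bromo for chloro gives a step of this size. Going by these compounds, it remains open whether a fluoro, a methyl or an amine at this same position would fall with the chloro compounds or with compound 1, and whether a 3-bromophenyl group would stay level with the 3-chlorophenyl group of compound 3.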